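The source may hold more compounds than are shown below. What is called first, only, known or untested is meant among the compounds shown, and "the series" means these compounds.

Measured so far:
compound 1 `O=C1C=C(Nc2ccc(I)cc2)C(=O)c2c1nc1n2[C@H]2OC[C@@H](O)[C@H]2OC1` — 1400 nM in a functional assay on MGC-803 cells (Homo sapiens) for inhibition, read by sulforhodamine B assay; on this read-out lower numbers stand for stronger inhibition and higher numbers for weaker inhibition
compound 2 `O=C1C=C(NCc2ccccc2)C(=O)c2c1nc1n2[C@H]2OC[C@@H](O)[C@H]2OC1` — 2670 nM in this assay
compound 3 `O=C1C=C(N2CCCCC2)C(=O)c2c1nc1n2[C@H]2OC[C@@H](O)[C@H]2OC1` — > 8000 nM in this assay

For compound 3 the value is a limit of the assay, not a number, and among the three values it is the one that sits at the limit of > 8000 nM in this assay, at which 1 of the 3 values shown sits. Compound 3 stands as the weakest of the three, since an at least 5.7-fold higher number from compound 1 to compound 3 (0.75 log units; beyond the scatter) and an at least 2.9-fold higher number from compound 2 to compound 3 (0.47 log units; beyond the scatter) are both beyond the scatter.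

Compound 4 `O=C1C=C(N2CCCC2)C(=O)c2c1nc1n2[C@H]2OC[C@@H](O)[C@H]2OC1` has not yet been measured. It differs from compound 3 by pyrrolidin-1-yl in place of piperidin-1-yl on a double-bonded ring carbon. For the measured compounds named here, both of the measured steps bear on it only loosely: they show that either of the two amines with a hydrogen on nitrogen, in compound 1 and compound 2, gives a lower number than the piperidin-1-yl of compound 3, but no step among the measured compounds changes one cyclic tertiary amine for another. The change from compound 3 to compound 4 is expected to give a step that the limit leaves unreadable from compound 3 to compound 4, that is none beyond the scatter. Compound 4 is therefore estimated at 10000 nM, with a range of 4000 nM to 25000 nM, and it is expected that the assay may again report only a limit.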

Compound 4, half-maximal inhibitory concentration: > 16000 nM
Compound 4: a limit, no number; the forecaster's own chance of this, stated with the estimate: 70%; middle value at least 1.6-fold (0.20 log units) from the limit.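

In this assay compound 4 gives > 16000 nM, which is a limit of the assay and not a number. Pyrrolidin-1-yl on the double-bonded ring carbon gives an at least 5.9-fold higher number from compound 2 to compound 4 (0.77 log units; beyond the scatter) and an at least 11-fold higher number from compound 1 to compound 4 (1.05 log units; beyond the scatter), so a second cyclic amine with no hydrogen on nitrogen also falls clearly short of both amines that carry one. The step between compound 3 and compound 4 cannot be read, so the two ring sizes cannot be ordered. Still open, from the compounds shown here alone, is whether cyclohexylamino, with a hydrogen on nitrogen and no aromatic ring, stays close to compound 1 and compound 2, and whether open-chain dimethylamino behaves like the two cyclic amines.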